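The compounds below may be only part of what the source reports. "The series", "measured", "known", "first", "only" and "open" are said of these compounds alone.

Measured compounds:
Compound 1 `Cc1cc(NC(=O)Cn2cc(-c3ccc([N+](=O)[O-])cc3)nn2)no1`: 1220 nM in a functional assay on BMDM cells (Mus musculus, strain C57BL/6) for inhibition, with a stated time of 2 days; a lower number here means a stronger inhibitor, a higher number a weaker inhibitor
Compound 2 `COc1ccc(-c2cn(CC(=O)Nc3nc4ccccc4s3)nn2)cc1`: 1330 nM in this assay
Compound 3 `Cc1csc(NC(=O)Cn2cc(-c3ccccc3Cl)nn2)n1`: 1240 nM in this assay

Compound 1 shows the lowest number of the three, yet its gaps to compound 3 and to compound 2 both lie within the usual scatter, so no ordering among them can be drawn. Compound 4 `COC(=O)c1ccc(-c2cn(CC(=O)Nc3cc(C)on3)nn2)cc1` has not yet been measured. It differs from compound 1 in one place: methoxycarbonyl in place of nitro on an aromatic carbon. For the measured compounds named here, no pair among the measured compounds tests this exchange, and the three values give no hint of direction. The expected step from compound 1 to compound 4 is a 1.1-fold higher number from compound 1 to compound 4 (0.06 log units; within the scatter), which amounts to no change beyond the scatter. Compound 4 is therefore estimated at 1400 nM in this assay, with a likely range from 600 nM to 3500 nM.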

Compound 4, half-maximal inhibitory concentration: > 30000 nM
Compound 4 ended at the assay's limit (the forecaster's own chance of this, stated with the estimate: 5%); middle value at least 21-fold (1.33 log units) away from the limit.
By their numbers in this assay, from the lowest: compounds 1, 3 and 2 (each within the scatter of the next). At a limit, above all of these: compound 4.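

At this position on the aromatic ring, para to a large group, the exchange of nitro for methoxycarbonyl is far from neutral: in this assay it gives an at least 24-fold higher number from compound 1 to compound 4 (1.39 log units; beyond the scatter). For the compounds shown here, no earlier pair tested this position, so this is the first sign that activity depends on the group there. The value of compound 4 is a limit, not a number: the limit of > 30000 nM in this assay, at which 1 of the 4 values shown sits.

From the compounds shown here alone, whether any group other than nitro keeps the activity of compound 1 stays open. So does how an amine, a carboxylic acid or a nitrile at this position would behave in this assay.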